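This account rests on a few compounds, and the source may have more. Where it says the series, first, only, none or still open, it means among the compounds named here.

Measured so far:
Compound 1 `O=C(/C=C/c1ccc(Cn2cc(Nc3ncc(Cl)c(Nc4ccc(F)cc4)n3)cn2)cc1)NO` gives 150 nM
Compound 2 `COc1ccc(Nc2nc(Nc3cnn(CCCCCCC(=O)NO)c3)ncc2Cl)cc1` gives 130 nM
Compound 3 `O=C(CCCCCn1cc(Nc2ncc(Cl)c(Nc3cccc(Cl)c3)n2)cn1)NO` gives 50 nM

All three values come from a functional assay on Jurkat cells (Homo sapiens) for antiproliferative activity, read by MTT assay, with a stated time of 48 h (on this read-out higher numbers stand for weaker inhibition and lower numbers for stronger inhibition), and the series is small. Compound 2 at 130 nM cannot be told apart from compound 1 at 150 nM, since the two lie within the usual scatter of repeated measurements. Compound 3 at 50 nM shows a lower number than compound 2, and that gap lies beyond the scatter, so it stands for stronger inhibition.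

The next molecule, compound 4 `O=C(CCCCCCn1cc(Nc2ncc(Cl)c(Nc3ccc(F)cc3)n2)cn1)NO`, changes compound 2 in one place only: fluoro in place of methoxy on an aromatic carbon. Fluoro takes the place of methoxy on an aromatic carbon, para to a large group, turning 4-methoxyphenyl into 4-fluorophenyl. Swapping a single group like this is the cleanest comparison a series can offer, yet no measured pair here shows this exact swap, so its size in this assay has no direct precedent. Compound 1 carries the same (4-fluorophenyl)amino group and gives 150 nM, although it differs elsewhere. That value offers no sign of a large shift, so no step beyond the scatter is expected, with at most a slight drift towards a lower number.

The expected change is a 1.2-fold lower number from compound 2 to compound 4 (0.09 log units; within the scatter), an estimate that stays within the scatter. For compound 4 the estimated value is 105 nM, with an expected range of 40 nM to 280 nM.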

Compound 4, half-maximal inhibitory concentration: 120 nM
The estimate for compound 4 lay 1.1-fold (0.06 log units) below the measured number; measured number inside the range.
By their numbers in this assay, from the lowest: compound 3; then compounds 4, 2 and 1 (each within the scatter of the next).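

In this assay, for the compounds shown here, putting fluoro in place of methoxy on an aromatic carbon, para to a large group, gives a 1.1-fold lower number from compound 2 to compound 4 (0.03 log units; within the scatter) and is the only direct reading of this swap. At this position, then, a group of one heavy atom can stand in for a group of two, and the hydrogen-bond acceptor counted for methoxy can go, with no change that can be told from the scatter of repeated measurements. No measured property of these compounds bears on why the two numbers match, so the result remains an observation without an explanation.

Going by these compounds, one swap cannot show how far this tolerance extends, and it remains open whether an amine, a carboxylic acid or a plain hydrogen at the same place would also leave the number within the scatter. Compound 3 differs from compound 4 in more than one place, so what separates its number remains unresolved until a shorter or longer chain can be compared with the aromatic substituent held constant.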